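Methyl removal at the ring amine of compound 2

The compounds below may be only part of what the source reports. "The series", "measured", "known", "first", "only" and "open" are said of these compounds alone.

Compound 2, `CNc1nc(SC)nc2c1ncn2[C@@H]1C[C@@H](O)[C@H](CO)O1`, sits at the detection limit in a functional assay on MOLT-4 cells (Homo sapiens) (on this read-out lower numbers stand for stronger inhibition and higher numbers for weaker inhibition), where compound 2 gives > 300 uM, a limit of the assay and not a number. Compound 1, `CN(C)c1nc(N)c2ncn([C@@H]3C[C@@H](O)[C@H](CO)O3)c2n1`, reports > 300 uM in this assay, likewise a limit. Going by the values given here, compound 3, `CNc1nc(Br)nc2c1ncn2[C@@H]1C[C@@H](O)[C@H](CO)O1`, gives 177 uM in this assay; the only single-point step measured so far, an at least 1.6-fold lower number from compound 2 to compound 3 (0.22 log units; that floor lies within the scatter), is a change on an aromatic carbon and is anchored at the limit of > 300 uM in this assay, at which 2 of the 3 values shown sit.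

Compound 4, `CSc1nc(N)c2ncn([C@@H]3C[C@@H](O)[C@H](CO)O3)c2n1`, differs from compound 2 by hydrogen in place of methyl on a nitrogen on an aromatic ring, that is, methylamino to amino. Among the compounds with values here, no measured step touches this nitrogen, and the one measured step from compound 2 runs through a limit, so nothing here sets the size or direction of the step to compound 4. The working expectation is therefore no step beyond the scatter, and the estimated step is a step that the limit leaves unreadable from compound 2 to compound 4. Compound 4 is accordingly expected to come out near 400 uM in this assay, with a range from 150 uM to 1500 uM, and most likely as a limit again rather than a number.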

Compound 4, concentration for 50% inhibition: > 300 uM
Compound 4: only a limit was reported; the forecaster's own chance of this, stated with the estimate: 75%; the middle value does not contradict the limit.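

In this assay compound 4 gives > 300 uM, a limit of the assay and not a number. The steps to compound 4 from compound 2 and from compound 1 join limits at both ends, so neither can be read. Still open, from the compounds shown here alone, is whether methylamino to amino changes inhibition at all, and whether any replacement other than bromo yields a number rather than a limit.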